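The compounds below may be only part of what the source reports. "The series", "measured", "known", "first", "only" and "open" are said of these compounds alone.

Of the compounds shown here, three built on one shared core have been measured in a physicochemical assay for lipophilicity, read by HPLC, measured as chromatographic lipophilicity, at pH 7.4; on this read-out higher numbers stand for higher lipophilicity and lower numbers for lower lipophilicity. Compound 1 `O=C(C1CCOCC1)N1N=CCC1c1ccccc1` gives 3.1, compound 2 `O=C(C1CCC1)N1N=CCC1c1ccccc1` gives 4.7, and compound 3 `O=C(C1CCOC1)N1N=CCC1c1ccccc1` gives 3, the lowest of the three numbers, although its gap to compound 1 lies within the scatter and only compound 2 stands clearly higher. Among the measured steps, a number 1.60 log units higher from compound 1 to compound 2 (beyond the scatter) and a number 1.70 log units lower from compound 2 to compound 3 (beyond the scatter), so exchanging a ring carrying an oxygen for a plain carbon ring moves this assay a great deal, whereas a number 0.10 log units lower from compound 1 to compound 3 (within the scatter), so the size of the oxygen-bearing ring hardly matters.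

Compound 4 `CC(C)(CO)C(=O)N1N=CCC1c1ccccc1` differs from compound 3 in one place: 1-(hydroxymethyl)-1-methylethyl in place of oxolan-3-yl on a carbonyl carbon. Among the measured compounds shown here, the entering group keeps one hydrogen-bond acceptor, adds one hydrogen-bond donor and has no ring; no measured step covers a donor, so the bearing steps are indirect. Because a number 0.10 log units lower from compound 1 to compound 3 (within the scatter) stayed within the scatter while the oxygen was kept, the expected step is a number 0.20 log units lower from compound 3 to compound 4 (within the scatter), a small drop or none beyond the scatter. Compound 4 is therefore estimated at 2.8, between 2.2 and 3.4.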

Compound 4, distribution coefficient: 3.4
The estimate for compound 4 lay 0.60 log units below the measured number; low and high end bracket the measured number.
By their numbers in this assay, from the lowest: compounds 3, 1 and 4 (each within the scatter of the next, the first and the last beyond it); then compound 2.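

In this assay, the open-chain 1-(hydroxymethyl)-1-methylethyl group on the carbonyl carbon, which has a hydrogen-bond donor that neither oxygen-bearing ring has, gives a number 0.40 log units higher from compound 3 to compound 4 (beyond the scatter) and a number 0.30 log units higher from compound 1 to compound 4 (within the scatter), so here the donor comes with no drop in the number. The oxygen-bearing groups still stay clearly apart from the plain carbon ring, with a number 1.30 log units lower from compound 2 to compound 4 (beyond the scatter), and this now holds for an open chain as well as for rings. The donor and the loss of the ring arrive together, so their separate shares cannot be told apart, and no measurement at hand offers an explanation for this result.

Going by these compounds, how an amine or a carboxylic acid would read in this place remains open. So does whether a plain tert-butyl group, the same chain without its hydroxyl, would match cyclobutyl.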